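The compounds below may be only part of what the source reports. "The series", "measured", "known", "first", "only" and "open" are said of these compounds alone.

Of the compounds shown here, three sharing one core have numbers so far in a functional assay on SW 1116 cells (Homo sapiens) for antiproliferative activity, read by MTT assay, with a stated time of 24 h; on this read-out lower numbers stand for stronger inhibition and higher numbers for weaker inhibition. Compound 1 `Sc1nnc(-c2ccc3c(c2)OCCO3)n1-c1ccccc1`, with only a hydrogen on its sulfur, gives 38400 nM. Compound 2 `c1ccc(CSc2nnc(-c3ccc4c(c3)OCCO4)n2-c2ccccc2)cc1`, with benzyl on that sulfur, gives 7930 nM, and compound 3 `Clc1ccccc1CSc1nnc(-c2ccc3c(c2)OCCO3)n1-c1ccccc1`, with 2-chlorobenzyl there, gives 9670 nM. Compound 2 thus stands level with compound 3, within the scatter, and both stand clearly lower than compound 1.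

Compound 4 `Cc1ccccc1CSc1nnc(-c2ccc3c(c2)OCCO3)n1-c1ccccc1` has not yet been measured. It differs from compound 2 in one place: methyl in place of hydrogen on an aromatic carbon. This is methyl in place of hydrogen on an aromatic carbon, ortho to a large group, so that benzyl becomes 2-methylbenzyl.

The closest guide is the change from benzyl to 2-chlorobenzyl, which gave a 1.2-fold higher number from compound 2 to compound 3 (0.09 log units; within the scatter). The larger steps came from placing a group on the sulfur at all, namely a 4.8-fold lower number from compound 1 to compound 2 (0.69 log units; beyond the scatter) and a 4.0-fold lower number from compound 1 to compound 3 (0.60 log units; beyond the scatter), and compound 4 keeps such a group. Only one substituted benzyl has been measured, so this guide is thin. No change beyond the scatter is therefore expected, and the step is estimated as a 1.1-fold higher number from compound 2 to compound 4 (0.05 log units; within the scatter). The expected value for compound 4 is 8800 nM, with an estimated range of 4500 nM to 17000 nM.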

Compound 4, half-maximal inhibitory concentration: 12700 nM
For compound 4 the middle estimate is 1.4-fold (0.16 log units) below the measured one, within the range that was stated.
By their numbers in this assay, from the lowest: compounds 2, 3 and 4 (each within the scatter of the next); then compound 1.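

In this assay, methyl on an aromatic carbon, ortho to a large group, gives a 1.6-fold higher number from compound 2 to compound 4 (0.20 log units; within the scatter) and so stays within the scatter of plain benzyl. Methyl in place of chloro at that same place gives a 1.3-fold higher number from compound 3 to compound 4 (0.12 log units; within the scatter) and also stays within the scatter, so 2-methylbenzyl, 2-chlorobenzyl and benzyl all read alike, and this place has now taken two different small groups without a step beyond the scatter. The gain from putting a group on the sulfur also holds for this third group, with a 3.0-fold lower number from compound 1 to compound 4 (0.48 log units; beyond the scatter) as the step, but no measurement explains why the methyl and chloro compounds read alike.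

The compounds shown leave open whether a group of another kind at this place, such as an amine or a carboxylic acid, would move the number beyond the scatter, and whether methyl or chloro elsewhere on the same ring would read the same. They also leave open how far the sulfur tolerates change, for example a longer chain such as 2-phenylethyl in place of benzyl.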